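Removing a methyl from the aryl ether of compound 3

The source may report more compounds than this note shows. Statements on the series, on what has been measured and on what is new or still open speak of the compounds shown alone.

The three measured compounds share a common core and carry a nitrile-bearing chain on it. Compound 1, `COc1cc(C)cc(-c2nn(CC#N)cc2-c2ccc(-c3cccc(C(C)=O)c3)nc2)c1`, gives 99% in a functional assay on BT-549 cells (Homo sapiens) for cytotoxicity, read by sulforhodamine B assay, with a stated time of 48 h, tested at 0.001 uM; a lower number here means a stronger effect, a higher number a weaker effect of the compound at the concentration tested. Compound 2, `Cc1cc(O)cc(-c2nn(CC#N)cc2-c2ccnc(-c3ccc(Oc4ccccc4)cc3)c2)c1`, gives 96% in this assay. Compound 3, `COc1cc(C)cc(-c2nn(CC#N)cc2-c2ccnc(-c3ccc(N(C)C)cc3)c2)c1`, gives 105% in this assay, a number that sits within the usual scatter of both compound 1 and compound 2, so the three compounds cannot be told apart on these readings.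

Compound 4, `Cc1cc(O)cc(-c2nn(CC#N)cc2-c2ccnc(-c3ccc(N(C)C)cc3)c2)c1`, has not yet been measured. It differs from compound 3 in one place: hydrogen in place of methyl on an oxygen on an aromatic ring. Compound 2 carries the same 3-hydroxy-5-methylphenyl group beside a different aryl partner and gives 96%, which sits with the other two numbers. On that basis, and because compound 3 gives 105%, no step beyond the scatter is expected for a number 5 percentage points lower from compound 3 to compound 4 (within the scatter). Compound 4 is therefore estimated to give 100% in this assay, within a range from 90% to 110%.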

Compound 4, a percentage reported as activity, at one concentration (the size of the read-out at that concentration, not a potency): 96%
Estimate against measurement, compound 4: 4 percentage points above; the measured number falls inside the stated range.
By their numbers in this assay, from the lowest: compounds 2, 4, 1 and 3 (each within the scatter of the next).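

In this assay, the change from methoxy to hydroxy on the 3-methoxy-5-methylphenyl group now has a direct reading, a number 9 percentage points lower from compound 3 to compound 4 (within the scatter), so at this concentration the methyl on that oxygen can go without a change that stands clear of the scatter. With the 3-hydroxy-5-methylphenyl group held, dimethylamino in place of phenoxy on an aromatic carbon gives no change at the digits printed from compound 2 to compound 4 (within the scatter), and this second place shows no separable effect either. Nothing available here accounts for either reading.

Going by these compounds, whether an ethyl or a longer chain on that oxygen, or an amine in place of the hydroxy, would move the number beyond the scatter remains open. Also open, on these data alone, is whether the four compounds would separate at other concentrations.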